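The source may report more compounds than this note shows. Statements on the series, on what has been measured and on what is new or still open speak of the compounds shown alone.

Measured so far:
compound 1 `COc1c(Br)cc(Br)cc1C(=O)Nc1ccccc1`, > 100000 nM
compound 2 `COc1c(Br)cccc1C(=O)Nc1ccccc1`, > 100000 nM
compound 3 `O=C(Nc1ccc(Sc2nc3ccccc3s2)cc1)c1cccc(Br)c1O`, 71000 nM

In an ADME assay on HEK293 cells (Homo sapiens) for cytotoxicity, read by reporter gene assay and resazurin assay, with a stated time of 48 h (a higher number here means that more compound is tolerated, a lower number that less compound is tolerated), compound 1 gives only a limit, > 100000 nM. Compound 2 likewise gives only a limit, > 100000 nM. Among the measured compounds shown here, compound 3 gives the one real number in this assay, 71000 nM. The change bromo in place of hydrogen on an aromatic carbon makes the step that the two limits leave unreadable from compound 2 to compound 1, which the limit of > 100000 nM in this assay, at which 2 of the 3 values shown sit, leaves unreadable. Compound 4 `O=C(Nc1ccc(Sc2nc3ccccc3s2)cc1)c1cc(Br)cc(Br)c1O` is not yet measured; it differs from compound 3 by bromo in place of hydrogen on an aromatic carbon. Around the place the two changes differ: in compound 1 the entering bromo is meta to a group of 9 heavy atoms and para to a methoxy group, in compound 4 it is meta to a large group and para to a hydroxy group, so this is the same kind of change, not the same change. The difference between the core of compound 2 and the core of compound 3 is not broken down here. From compound 3 to compound 4 a step of a 1.4-fold lower number from compound 3 to compound 4 (0.15 log units; within the scatter) is expected in this assay. That expectation rests on the step that the two limits leave unreadable from compound 2 to compound 1 being unreadable and on compound 3 giving 71000 nM. Compound 4 is estimated at 50000 nM, expected between 20000 nM and 150000 nM.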

Compound 4, half-maximal cytotoxic concentration: 66000 nM
Compound 4: middle estimate off by 1.3-fold (0.12 log units), on the low side; the measured number falls inside the stated range.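

In this assay, bromo in place of hydrogen on an aromatic carbon, para to a hydroxy group, gives a 1.1-fold lower number from compound 3 to compound 4 (0.03 log units; within the scatter). This is a single pair on one core and sets no rule for the series. The same kind of change, para to a methoxy group on the core of compound 2, gives a step that cannot be read, so carrying the change from one core to the other is neither supported nor contradicted, because the values on that core are limits of the assay: the limit of > 100000 nM in this assay, at which 2 of the 4 values shown sit.

Still open, going by these compounds, is how an amine or a carboxylic acid would read in place of bromo at this position. Also open, on these data alone, is how the 3,5-dibromo-2-hydroxyphenyl group would read on the core of compound 2.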